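This account rests on a few compounds, and the source may have more. Where it says the series, first, only, none or still open, it means among the compounds named here.

Measured so far in a functional assay on HeLa cells (Homo sapiens) for antiproliferative activity, with a stated time of 24 h; on this read-out lower numbers stand for stronger inhibition and higher numbers for weaker inhibition:
compound 1 `NC(=O)c1c(NC(=O)c2ccc(C(F)(F)F)cc2)sc2c1CCN(Cc1ccc(Cl)cc1)C2`: compound 1 reaches only > 50000 nM, a limit of the assay.
compound 2 `NC(=O)c1c(NC(=O)c2ccccc2F)sc2c1CCN(Cc1c(Cl)cccc1Cl)C2`: compound 2 gives 33000 nM.
compound 3 `NC(=O)c1c(NC(=O)c2ccccc2Cl)sc2c1CCN(C(=O)Nc1ccccc1Cl)C2`: compound 3 gives 45400 nM.

All three are weak. Compound 3 and compound 2 sit within the usual scatter of each other, while compound 1 remains a limit and not a number. Going by the values given here, no two measured compounds differ in a single place, so no measured step exists in this set.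

Compound 4 `NC(=O)c1c(NC(=O)c2ccccc2Cl)sc2c1CCN(C(=S)Nc1cccnc1)C2` differs from compound 3 as follows: a group of 9 heavy atoms (6 carbon, 2 nitrogen, 1 sulfur; one six-membered aromatic ring with 1 hetero atom) in place of a group of 10 heavy atoms (7 carbon, 1 nitrogen, 1 oxygen, 1 chlorine; one six-membered aromatic ring of carbon only), on an amine nitrogen in a ring. Nothing in the measured data speaks to this change, and the series as a whole is weak. A step of no size beyond the scatter is expected in this assay. Compound 4 is therefore estimated at 40000 nM, between 15000 nM and 100000 nM. The expected step of a 1.1-fold lower number from compound 3 to compound 4 (0.05 log units; within the scatter) is estimated to stay within the scatter.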

Compound 4, half-maximal inhibitory concentration: > 50000 nM
Compound 4 ended at the assay's limit; the forecaster's own chance of this, stated with the estimate: 35%; middle value at least 1.2-fold (0.09 log units) away from the limit.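

In this assay, going by these compounds alone, the exchange on the amine nitrogen in a ring gives the first measured step in this set: an at least 1.1-fold higher number from compound 3 to compound 4 (0.04 log units; that floor lies within the scatter). Compound 4 gives > 50000 nM, which is a limit of the assay and not a number. The step therefore sets only a floor, and the read-out often ends at this limit: the limit of > 50000 nM in this assay, at which 2 of the 4 values shown sit.

The compounds shown do not separate the sulfur from the hetero atom in the aromatic ring. On these data alone, it also stays open whether an acetyl group or an aminoethyl chain on this nitrogen would give a lower number.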